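This account rests on a few compounds, and the source may have more. Where it says the series, first, only, none or still open, it means among the compounds named here.

The study compares two pairs of compounds in a functional assay on HT-1080 cells (Homo sapiens) for antiproliferative activity, read by MTT assay, with a stated time of 72 h; a higher number here means a weaker inhibitor, a lower number a stronger inhibitor. Compound 1 `COc1ccc(-c2sc(C(=O)O)cc2-c2cc(OC)c(OC)c(OC)c2)cc1` carries a carboxylic acid on its core; in this assay compound 1 gives 6770 nM. Compound 2 `COc1ccc(-c2sc(C(=O)O)cc2-c2cc(OC)c(OC)c(OC)c2)cc1[N+](=O)[O-]` differs from compound 1 by nitro in place of hydrogen on an aromatic carbon, and in this assay compound 2 gives 37200 nM. That single change produced a 5.5-fold higher number from compound 1 to compound 2 (0.74 log units; beyond the scatter).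

Compound 3 `COc1ccc(-c2ccsc2-c2cc(OC)c(OC)c(OC)c2)cc1` has a different core without the carboxylic acid; how its core differs from the core of compound 1 is not broken down here. In this assay compound 3 gives 3620 nM, a value whose distance from compound 1 lies within the usual scatter of repeated measurements, while its distance from compound 2 lies beyond that scatter.

Compound 4 `COc1ccc(-c2ccsc2-c2cc(OC)c(OC)c(OC)c2)cc1[N+](=O)[O-]` has not yet been measured. It differs from compound 3 by nitro in place of hydrogen on an aromatic carbon, the same change, made at the same place, as that from compound 1 to compound 2. The expectation for compound 4 rests on that single precedent: one expects the step from compound 3 to compound 4 in this assay to be of similar size, estimated as a 5.5-fold higher number from compound 3 to compound 4 (0.74 log units; beyond the scatter), because the corresponding change gave a 5.5-fold higher number from compound 1 to compound 2 (0.74 log units; beyond the scatter). On that basis compound 4 is expected to give about 20000 nM in this assay, with a plausible range from 7000 nM to 60000 nM. Whether the second core answers the change in the same way as the first remains to be seen.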

Compound 4, half-maximal inhibitory concentration: 8040 nM
The estimate for compound 4 lay 2.5-fold (0.40 log units) above the measured number, within the range that was stated.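

In this assay, nitro in place of hydrogen on an aromatic carbon, ortho to a methoxy group, acted in the same direction on the second core as on the first, giving a 2.2-fold higher number from compound 3 to compound 4 (0.35 log units; beyond the scatter), so on both cores the change moved the number up by more than the usual scatter. Within the data shown here, the two steps cannot be told apart in size, and the change carried over from one core to the other, in direction and within the scatter in size: the same change on two cores in this assay, a 5.5-fold higher number (0.74 log units; beyond the scatter) from compound 1 to compound 2 and a 2.2-fold higher number (0.35 log units; beyond the scatter) from compound 3 to compound 4, 2.5-fold (0.39 log units) apart, within the scatter of two such steps This rests on only two pairs of compounds, however, so it does not show that the change would act alike on any further core, and it offers no explanation of why the change weakens these compounds.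

The compounds shown leave open how an amine, a nitrile or a fluorine at that same place would fare on either core, and whether an ester or an amide in place of the carboxylic acid of compound 1 would alter the step. They also leave open whether the step seen in this assay would hold on other cells or in another kind of assay.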